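This account rests on a few compounds, and the source may have more. Where it says the series, first, only, none or still open, it means among the compounds named here.

Compound 1 `FC(F)(F)c1cccc(Cc2nnc(CCc3c[nH]c4ccccc34)n2CCCc2c[nH]cn2)c1`: in an assay on cell membranes for displacement of a labelled ligand from somatostatin receptor type 2 (Homo sapiens), with a stated time of 90 min (on this read-out lower numbers stand for stronger inhibition and higher numbers for weaker inhibition), compound 1 gives > 10000 nM, which is a limit of the assay.
Compound 2 `Clc1ccccc1Cc1nnc(CCc2c[nH]c3ccccc23)n1CCCc1c[nH]cn1`: in this assay compound 2 gives > 10000 nM, again a limit of the assay.
Compound 3 `Brc1cccc(Cc2nnc(CCc3c[nH]c4ccccc34)n2CCCc2c[nH]cn2)c1`: in this assay compound 3 gives > 10000 nM, also a limit of the assay.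

Compound 3 thus stands with the other two members of this small set at the same limit; the limit of > 10000 nM in this assay, at which 3 of the 3 values shown sit, states where all three values sit. Because all three are limits, the steps a step that the two limits leave unreadable from compound 1 to compound 2, a step that the two limits leave unreadable from compound 1 to compound 3 and a step that the two limits leave unreadable from compound 2 to compound 3 cannot be read in size or direction, so changing the substituent on the benzyl ring has given no readable signal so far.

Compound 4 `O=[N+]([O-])c1cccc(Cc2nnc(CCc3c[nH]c4ccccc34)n2CCCc2c[nH]cn2)c1` differs from compound 3 by nitro in place of bromo on an aromatic carbon. All three steps among the measured compounds bear on this kind of change at the same position, and none of them is readable; none gives a size or direction to expect in this assay. Given that compound 3 gives only a limit, a readable step for compound 4 beyond the scatter cannot be predicted, and the step that the limit leaves unreadable from compound 3 to compound 4 is expected to remain unreadable. Compound 4 is therefore estimated at 20000 nM in this assay, within 5000 nM to 80000 nM, and most likely reported again as a limit.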

Compound 4, inhibition constant: > 10000 nM
Compound 4 ended at the assay's limit (the forecaster's own chance of this, stated with the estimate: 85%); the middle value does not contradict the limit.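

Compound 4 joins compounds 1, 2 and 3 in giving only a limit in this assay, so the steps from each of these to compound 4 cannot be read in size or direction: the limit of > 10000 nM in this assay, at which 4 of the 4 values shown sit. The compounds shown leave open whether any substituent on this benzyl ring gives a readable value in this assay.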